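This account rests on a few compounds, and the source may have more. Where it says the series, first, only, none or still open, it means among the compounds named here.

In a toxicity assay on MT4 cells (Homo sapiens) for cytotoxicity, read by MTT assay, with a stated time of 5 days (a higher number here means that more compound is tolerated, a lower number that less compound is tolerated), compound 1 `Cc1cc(-c2cccs2)cc(C)c1Nc1ccnc(Nc2ccc(C#N)cc2)n1` gives 10000 nM and compound 2 `Cc1cc(-c2ccc3cc[nH]c3c2)cc(C)c1Nc1ccnc(Nc2ccc(C#N)cc2)n1` gives 5800 nM while compound 3 `Cc1cc(-c2cc(C)c(Nc3ccnc(Nc4ccc(C#N)cc4)n3)c(C)c2)ccn1` gives 4900 nM on the same shared core. Compound 3 therefore sits with compound 2, as a 1.2-fold lower number from compound 2 to compound 3 (0.07 log units; within the scatter) shows, and apart from compound 1, as a 2.0-fold lower number from compound 1 to compound 3 (0.31 log units; beyond the scatter) shows. The remaining measured step, a 1.7-fold lower number from compound 1 to compound 2 (0.24 log units; within the scatter), is also small. Compound 4 `Cc1cc(-c2ccnc(F)c2)cc(C)c1Nc1ccnc(Nc2ccc(C#N)cc2)n1` keeps all of compound 3 except one group: fluoro in place of methyl on an aromatic carbon turns 2-methylpyridin-4-yl into 2-fluoropyridin-4-yl. Among the measured compounds shown here, no measured step makes this exact exchange, so the three steps above bear on it only indirectly. They replace a whole aromatic group, a larger edit than fluoro in place of methyl, and the largest of them is a 2.0-fold lower number from compound 1 to compound 3 (0.31 log units; beyond the scatter) and only modest. In this assay the expected step is therefore a 1.1-fold higher number from compound 3 to compound 4 (0.05 log units; within the scatter) which would lie within the scatter, with no direction that the data can support. For compound 4 the estimated value is 5500 nM with an expected range of 2500 nM to 12000 nM around it.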

Compound 4, half-maximal cytotoxic concentration: 6000 nM
The estimate for compound 4 lay 1.1-fold (0.04 log units) below the measured number; the measured number falls inside the stated range.
By their numbers in this assay, from the lowest: compounds 3, 2, 4 and 1 (each within the scatter of the next, the first and the last beyond it).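

In this assay the exact exchange now has a measured step: at this place next to the ring nitrogen, fluoro in place of methyl gives a 1.2-fold higher number from compound 3 to compound 4 (0.09 log units; within the scatter) and so leaves the tolerated concentration within the usual scatter. Among the compounds shown here, the 2-fluoropyridin-4-yl group also stays close to the larger exchanges at the same carbon, with a 1.0-fold higher number from compound 2 to compound 4 (0.01 log units; within the scatter) against 1H-indol-6-yl and a 1.7-fold lower number from compound 1 to compound 4 (0.22 log units; within the scatter) against thiophen-2-yl, so the only step beyond the scatter on this position remains a 2.0-fold lower number from compound 1 to compound 3 (0.31 log units; beyond the scatter) and it is modest. No measurement of any other property accompanies these compounds, so this closeness can only be described and not explained.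

What the compounds shown leave open is whether this place stays as tolerant of groups of another kind, such as an amine, a methoxy group or a carboxylic acid in place of fluoro. They also leave open whether a ring carrying no nitrogen, such as a plain phenyl, would fall within the same narrow band.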